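A few compounds are considered here, and "the series" means these few. Any claim that something is new, unique, unknown or untested is made for them only; others in the source may bear on it.

Measured in an assay on BaF3 cells for inhibition of proto-oncogene tyrosine-protein kinase receptor Ret variant V804M (Homo sapiens), read by MTT assay, with a stated time of 48 h; on this read-out lower numbers stand for stronger inhibition of growth and higher numbers for weaker inhibition of growth:

Compound 1 `CC(C)n1nc(-c2cc(C3CCCCC3)on2)c2c(N)ncnc21` gives 4730 nM.
Compound 2 `CC(C)n1nc(/C=N/OCc2ccccc2)c2c(N)ncnc21` gives only a limit of the assay, > 10000 nM.
Compound 3 `Nc1ncnc2c1c(-c1cc(C3CC3)on1)nn2C1CCOCC1` gives 1930 nM.

Among the two compounds with a numeric result in this assay, compound 1 stands at the higher number, and compound 3 sits lower by a gap beyond the usual scatter. Compound 2 differs from both in its side chain and gives no number at all; only the limit of > 10000 nM in this assay, at which 1 of the 3 values shown sits, describes it.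

Compound 4 `CC(C)c1cc(-c2nn(C(C)C)c3ncnc(N)c23)no1` keeps the shared core and the same isopropyl group on the ring nitrogen as compound 1, but the change is isopropyl in place of cyclohexyl on an aromatic carbon. Going by the values given here, no measured pair shows exactly this exchange. Compound 3, which carries the smaller cyclopropyl on that ring together with a different group on the ring nitrogen, gives 1930 nM, so a shift toward lower numbers is plausible but not secured. Compound 4 is estimated to land near compound 1, with only a modest improvement expected, the step of a 1.4-fold lower number from compound 1 to compound 4 (0.13 log units; within the scatter). Compound 4 is expected to give 3500 nM, with a range from 1200 nM to 10000 nM.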

Compound 4, concentration for 50% growth inhibition: 5900 nM
Compound 4: middle estimate off by 1.7-fold (0.23 log units), on the low side; the range from low to high includes it.
By their numbers in this assay, from the lowest: compound 3; then compounds 1 and 4 (each within the scatter of the next). At a limit, above all of these: compound 2.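

In this assay, replacing cyclohexyl with isopropyl on the aromatic carbon next to the ring oxygen, with the rest of the molecule unchanged, gives a 1.2-fold higher number from compound 1 to compound 4 (0.10 log units; within the scatter). Going by these compounds alone, this is the first direct reading at this position, and it shows that going from a six-membered carbon ring of 6 heavy atoms to an open group of 3 heavy atoms leaves the result within the scatter. The compounds shown offer no explanation for this flat step.

Going by these compounds, whether an amine or a carboxylic acid on this carbon would move the number remains open, as both groups compared here are plain carbon groups. Also open, on these data alone, is what cyclopropyl contributes at this position on its own, with the isopropyl group kept on the ring nitrogen.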